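This account rests on a few compounds, and the source may have more. Where it says the series, first, only, none or still open, it means among the compounds named here.

Measured compounds:
compound 1 `CCCCCCCCOC(=O)CCC(=O)N1CCN(CCCOc2cc3c(Nc4ccc(F)c(Cl)c4)ncnc3cc2OC)CC1`, which in a functional assay on A549 cells (Homo sapiens) for cytotoxicity, read by MTT assay, with a stated time of 24 h, tested at 80 uM (on this read-out higher numbers stand for a weaker effect at the one concentration tested and lower numbers for a stronger effect), gives 21.7%
compound 2 `CCCCCCCCCCOC(=O)CCC(=O)N1CCN(CCCOc2cc3c(Nc4ccc(F)c(Cl)c4)ncnc3cc2OC)CC1`, which in this assay gives 2%
compound 3 `CCCCCCCCCCCOC(=O)CCC(=O)N1CCN(CCCOc2cc3c(Nc4ccc(F)c(Cl)c4)ncnc3cc2OC)CC1`, which in this assay gives 2.8%

All three compounds share one core and differ only in the length of the saturated chain attached through an oxygen next to a carbonyl group. Compound 3 stands second highest of the three numbers. Its nearest neighbour is compound 2, separated by a number 0.8 percentage points higher from compound 2 to compound 3 (within the scatter), a gap that lies within the scatter of repeated measurements. Its furthest neighbour is compound 1, and the step of a number 18.9 percentage points lower from compound 1 to compound 3 (beyond the scatter) is a modest one beyond the scatter.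

Compound 4 `CCCCCCCCCCCCCCCCOC(=O)CCC(=O)N1CCN(CCCOc2cc3c(Nc4ccc(F)c(Cl)c4)ncnc3cc2OC)CC1` differs from compound 3 by pentyl in place of hydrogen on a saturated chain carbon, ten or more bonds along the chain from an oxygen next to a carbonyl group. Going by the values given here, two measured steps bear on this kind of change. Lengthening the chain from compound 1 gave a number 19.7 percentage points lower from compound 1 to compound 2 (beyond the scatter) and a number 18.9 percentage points lower from compound 1 to compound 3 (beyond the scatter), both modest. Lengthening it further gave only a number 0.8 percentage points higher from compound 2 to compound 3 (within the scatter), within the scatter. The numbers for compound 2 and compound 3 already sit close to the bottom of the scale, so a further extension is expected to leave little room for a downward step, and the expected step is a number 1.2 percentage points higher from compound 3 to compound 4 (within the scatter), not beyond the scatter. Compound 4 is therefore estimated at 4%, with a range from 0% to 15%.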

Compound 4, a percentage reported as activity, at one concentration (the size of the read-out at that concentration, not a potency): 74.3%
Compound 4: middle estimate off by 70.3 percentage points, on the low side; measured number above the stated range.
By their numbers in this assay, from the lowest: compounds 2 and 3 (each within the scatter of the next); then compound 1; then compound 4.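

Lengthening this saturated chain does not keep strengthening the effect in this assay: the flat stretch seen between compound 2 and compound 3 gives way to a sharp reversal, with a number 71.5 percentage points higher from compound 3 to compound 4 (beyond the scatter) when pentyl replaces the hydrogen at this far position, and a number 72.3 percentage points higher from compound 2 to compound 4 (beyond the scatter) for the matching hexyl change. The reversal even overshoots the starting point, since the octyl change gives a number 52.6 percentage points higher from compound 1 to compound 4 (beyond the scatter), so the chain of compound 4 leaves it the weakest of the four at the one concentration tested, whereas compound 1, with the shortest chain here, still has a clearly stronger effect, and the link between chain length and effect therefore falls and then rises rather than running in one direction. The data at hand offer no measurement that accounts for this reversal.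

The compounds shown leave open where along the chain the number starts to climb, a point that a propyl or butyl in the same place on compound 3 would help to narrow. They also leave open whether a still longer chain stays as weak as compound 4, and whether an amine or a carboxylic acid at the far end of a long chain would change the picture.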